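The compounds below may be only part of what the source reports. "The series", "measured", "known", "first", "only" and "open" are said of these compounds alone.

Of the compounds shown here, three built on one shared core have been tested in a toxicity assay on THP-1 cells (Homo sapiens) for inhibition; on this read-out higher numbers stand for lower toxicity in this test and lower numbers for higher toxicity in this test. Compound 1 `COc1ccc(-c2cnc(NC(=O)c3ccccn3)n2C)cc1` carries a pyridin-2-yl on its carbonyl carbon. In this assay compound 1 gives > 100000 nM, which is a limit of the assay rather than a number. Compound 3 `COc1ccc(-c2cnc(NC(C)=O)n2C)cc1` has a methyl in place of that pyridin-2-yl, and in this assay compound 3 gives > 100000 nM, again a limit. The step that the two limits leave unreadable from compound 1 to compound 3 is therefore unreadable. Compound 2 `COc1ccc(-c2cn(C)c(NC(=O)c3ccc(F)cc3)n2)cc1` is the starting point here, and in this assay compound 2 gives > 50000 nM, once more a limit. So compound 2 stands only at a limit, with no number, and the two other values shown are limits too: the limit of > 100000 nM in this assay, at which 2 of the 3 values shown sit, and (the limit of > 50000 nM in this assay, at which 1 of the 3 values shown sits).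

The new compound 4 `Cn1cc(-c2ccccc2)nc1NC(=O)c1ccc(F)cc1` differs from compound 2 in one place, (hydrogen in place of methoxy on an aromatic carbon). No measured step touches this part of the molecule, so nothing shown speaks directly to the size or direction of the change. All three measured values sit at limits, which gives no sign of measurable toxicity anywhere in the set. The step from compound 2 to compound 4 is accordingly expected to be a step that the limit leaves unreadable from compound 2 to compound 4. Compound 4 is estimated at 60000 nM, within 20000 nM to 200000 nM.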

Compound 4, half-maximal cytotoxic concentration: > 50000 nM
Compound 4 gave a limit, no number (the forecaster's own chance of this, stated with the estimate: 70%); the middle value does not contradict the limit.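

Compound 2 and compound 4 both stand at a limit rather than a number in this assay, so no step can be read from the change of methoxy to hydrogen. The compounds shown leave open at what concentration any of them would become toxic to these cells, and whether that change matters at all.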